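This account rests on a few compounds, and the source may have more. Where it says the series, first, only, none or still open, it means among the compounds named here.

Measured compounds in the series:

compound 1, `COc1ccc(-n2cc3nc(-c4cccnc4C)n(C[C@H]4CCCN(C[C@H]5CCCO5)C4)c(=O)c3n2)cc1`, 52 nM
compound 2, `COc1cccc(-n2cc3nc(-c4cccnc4C)n(C[C@H]4CCCN(Cc5ccco5)C4)c(=O)c3n2)c1`, 2.7 nM
compound 3, `Cc1ccccc1-c1nc2cn(-c3ccc(Cl)cc3)nc2c(=O)n1CC1CCCN(C(C)C)C1`, 0.28 nM

All three values come from an assay on HEK293 cells for displacement of a labelled ligand from growth hormone secretagogue receptor type 1 (Homo sapiens), with a stated time of 60 min; on this read-out higher numbers stand for weaker inhibition and lower numbers for stronger inhibition. Compound 2 sits between the other two: its number is higher than that of compound 3 and lower than that of compound 1, and both of those gaps are beyond the scatter, so the order is firm. Compound 1 and compound 3 differ from compound 2 in more than one place each, so neither pair isolates a single change.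

Compound 4, `COc1cccc(-n2cc3nc(-c4cccnc4C)n(C[C@H]4CCCN(Cc5cnco5)C4)c(=O)c3n2)c1`, is the next member and has not been measured in this assay. It differs from compound 2 by 1,3-oxazol-5-yl in place of furan-2-yl on a saturated chain carbon bound to an amine nitrogen in a ring. Within the data shown here, nothing among the measured compounds shows the effect of this particular exchange, and the surrounding structure is otherwise kept. Among the measured compounds shown here, with no comparable step to lean on, the expected change is small: the number for compound 4 is expected to move little from that of compound 2, with a slight drift upward seen as the more likely direction, but a difference within the scatter would not be surprising.

The step from compound 2 to compound 4 is therefore estimated as a 1.7-fold higher number from compound 2 to compound 4 (0.22 log units; within the scatter). For compound 4 the value in this assay is estimated at 4.5 nM, with a range from 1.5 nM to 14 nM.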

Compound 4, half-maximal inhibitory concentration: 120 nM
For compound 4 the middle estimate is 27-fold (1.43 log units) below the measured one, and the stated range ends below it.
By their numbers in this assay, from the lowest: compound 3; then compound 2; then compound 1; then compound 4.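

In this assay, among these compounds, this exchange is the first step that changes one place only, and it is large: a 44-fold higher number from compound 2 to compound 4 (1.65 log units; beyond the scatter). The leaving and entering groups both have 5 heavy atoms and a five-membered aromatic ring, going from 1 to 2 hetero atoms and from 1 to 2 hydrogen-bond acceptors, so on a saturated chain carbon bound to an amine nitrogen in a ring, the read-out can shift strongly with no change in ring size. No measurement at hand gives a reason for this step.

A single pair cannot show whether the weakening belongs to the ring nitrogen of 1,3-oxazol-5-yl itself or to its placement in the ring, and groups such as thiophen-2-yl, 1,3-oxazol-2-yl or pyridin-3-yl on the same carbon would bear on that question. From the compounds shown here alone, whether a step of this size carries over to compounds with other groups elsewhere on the shared core also remains open.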